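The source may hold more compounds than are shown below. What is called first, only, known or untested is meant among the compounds shown, and "the series" means these compounds.

The set rests on one shared core, carried by compound 1 `Cc1cc(C(=O)O)ccc1-c1noc(-c2ccc(C3CCCCC3)cc2)n1`, compound 2 `Cc1cc(CCC(=O)O)ccc1-c1noc(-c2ccc(OC(C)C)c(C(F)(F)F)c2)n1` and compound 3 `Cc1cc(CCC(=O)O)ccc1-c1noc(-c2ccc(OC(C)C)c(F)c2)n1`. In a functional assay on CHO cells for agonist activity at sphingosine 1-phosphate receptor 5 (Homo sapiens), read by GTPgammaS binding (a higher number here means that more compound is needed for the effect, a lower number that less compound is needed), compound 1 reaches only > 10000 nM, which is a limit of the assay rather than a number (the limit of > 10000 nM in this assay, at which 1 of the 3 values shown sits). Compound 2 gives 40 nM in this assay. Compound 3 gives 530 nM in this assay, the highest of the two numbers in the set. Within the data shown here, the single measured step, a 13-fold higher number from compound 2 to compound 3 (1.12 log units; beyond the scatter), shows how much this assay moves when the group on that aromatic carbon changes.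

Compound 4 `Cc1cc(CCC(=O)O)ccc1-c1noc(-c2ccc(OC(C)C)c(Cl)c2)n1` has not yet been measured. It differs from compound 3 in one place: chloro in place of fluoro on an aromatic carbon. Among the measured compounds shown here, the only measured step that bears on this exchange is a 13-fold higher number from compound 2 to compound 3 (1.12 log units; beyond the scatter), a large one, in which a different group left that same aromatic carbon and fluoro entered. Replacing fluoro with chloro is an exchange of the same kind, so a step back down in this assay is expected, though a smaller one than the measured step. The estimate for compound 4 is 150 nM, with a range from 50 nM to 500 nM. That estimate corresponds to an expected step of a 3.5-fold lower number from compound 3 to compound 4 (0.55 log units; beyond the scatter).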

Compound 4, half-maximal effective concentration: 140 nM
Compound 4: the middle estimate sits 1.1-fold (0.03 log units) above what was measured; low and high end bracket the measured number.
By their numbers in this assay, from the lowest: compound 2; then compound 4; then compound 3. At a limit, above all of these: compound 1.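

Among these compounds, at the aromatic carbon ortho to an isopropoxy group, the earlier compounds offered only two groups to set side by side, and a third group now shows that this position gives more than a two-way contrast. In this assay, a 3.8-fold lower number from compound 3 to compound 4 (0.58 log units; beyond the scatter) and a 3.5-fold higher number from compound 2 to compound 4 (0.54 log units; beyond the scatter) together place chloro between fluoro and trifluoromethyl, and each of these steps lies beyond the scatter. The exchange of fluoro for chloro swaps one heavy atom for one heavy atom, with no hydrogen-bond donor or acceptor and no net charge on either side, yet that is enough to move the number in this assay.

The compounds shown leave open where other groups on this same carbon would fall in this order, such as a bromo group, a methyl group, a methoxy group or a nitrile, and whether the same order would hold with a group other than isopropoxy beside it. Nothing measured in this set speaks to why the number follows this order among the three groups.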